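Compound 4 after an inactive aryl lactam neighbour

This account rests on a few compounds, and the source may have more. Where it says the series, first, only, none or still open, it means among the compounds named here.

compound 1 `O=C1COc2ccc(-c3cccc(NS(=O)(=O)c4ccc(F)cc4)c3)cc2N1` gives 18300 nM
compound 2 `COc1cccc(N2C(=O)COc3ccc(-c4cnc(OC)c(NS(=O)(=O)c5ccc(F)cc5)c4)cc32)c1` gives > 40000 nM (a limit)
compound 3 `COc1cccc(N2C(=O)COc3ccc(-c4cnc5ccccc5c4)cc32)c1` gives > 40000 nM (a limit)

In a functional assay on MCF7 cells (Homo sapiens) for antiproliferative activity, read by MTT assay, with a stated time of 72 h (a lower number here means a stronger inhibitor, a higher number a weaker inhibitor), compound 1 gives a true number, 18300 nM. Compound 2 reaches only a limit, > 40000 nM. Compound 3 also gives only a limit, > 40000 nM, and so has no number of its own. This is the limit of > 40000 nM in this assay, at which 2 of the 3 values shown sit.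

Compound 4 `Cc1ccc(N2C(=O)COc3ccc(-c4cnc5ccccc5c4)cc32)cc1` keeps the core of compound 3 but carries 4-methylphenyl in place of 3-methoxyphenyl on an amide-type nitrogen in a ring. Among the measured compounds shown here, no measured pair in this small set shows such a swap, so the expectation has little to rest on beyond compound 3 and its limit of > 40000 nM. No change beyond the scatter is expected in this assay, and the estimated step is a number no higher from compound 3 to compound 4 (the limit leaves the size open). A reading that again returns only the limit would be unsurprising. Compound 4 is expected at 40000 nM, with an estimated range from 15000 nM to 100000 nM.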

Compound 4, half-maximal inhibitory concentration: > 40000 nM
Compound 4 gave a limit, no number; the forecaster's own chance of this, stated with the estimate: 70%; the middle value lies on the limit itself.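

Compound 4 gives only a limit, > 40000 nM. Compound 3 also stands at a limit, so no step can be read between compound 3 and compound 4: the limit of > 40000 nM in this assay, at which 3 of the 4 values shown sit.

As far as these compounds go, whether 4-methylphenyl and 3-methoxyphenyl on the amide-type nitrogen in a ring differ at all in antiproliferative activity stays open.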